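This account rests on a few compounds, and the source may have more. Where it says the series, first, only, none or still open, it means among the compounds named here.

Compound 1 `O=C(N/N=C/c1ccccc1O)c1cc(-c2ccccc2)nn1Cc1ccc(Cl)nc1`: 45000 nM
Compound 2 `COc1ccc(/C=N/NC(=O)c2cc(-c3ccccc3)nn2Cc2ccc(Cl)nc2)cc1`: 15000 nM

In a functional assay on A549 cells (Homo sapiens) for cytotoxicity, read by MTT assay, with a stated time of 48 h (on this read-out higher numbers stand for higher solubility and lower numbers for lower solubility), compound 1 stands highest of the two numbers, with compound 2 giving 15000 nM and a 3.0-fold lower number from compound 1 to compound 2 (0.48 log units; beyond the scatter). Compound 3 `O=C(N/N=C/c1ccccc1O)c1cc(-c2ccc(Cl)cc2)nn1Cc1ccc(Cl)nc1` differs from compound 1 by chloro in place of hydrogen on an aromatic carbon. For the measured compounds named here, the only measured step, the one from compound 1 to compound 2, changes the aryl group on the carbon with a double bond to nitrogen, a different part of the molecule, so it bears only loosely on this change. For compound 3 a step no larger than the scatter is expected, a 1.4-fold lower number from compound 1 to compound 3 (0.15 log units; within the scatter). The estimate for compound 3 is 32000 nM, within a range of 12000 nM to 70000 nM.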

Compound 3, solubility: 22500 nM
The estimate for compound 3 lay 1.4-fold (0.15 log units) above the measured number, and the stated range covers the measured number.
By their numbers in this assay, from the lowest: compounds 2, 3 and 1 (each within the scatter of the next, the first and the last beyond it).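

In this assay, the change from phenyl to 4-chlorophenyl gives a 2.0-fold lower number from compound 1 to compound 3 (0.30 log units; within the scatter). For the compounds shown here, the earlier step changed only the aryl group on the carbon with a double bond to nitrogen, so this is the first reading at this phenyl group, and here one chlorine leaves the number within the usual scatter. No supporting measurement explains this result. From the compounds shown here alone, whether an amine or a carboxylic acid at the same place would also stay within the scatter remains open. So does whether chloro would give a similar step on compound 2.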